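Ethoxy to Carbamoylmethoxy on a Nucleoside-Like Inhibitor

The source may report more compounds than this note shows. Statements on the series, on what has been measured and on what is new or still open speak of the compounds shown alone.

Compound 1 `Nc1ncnc2c1nc(NCc1ccc(-c3ccncc3)cc1)n2[C@@H]1O[C@H](CO)[C@@H](O)[C@H]1O`: 2700 nM
Compound 2 `CCOc1cc(CNc2nc3c(N)ncnc3n2[C@@H]2O[C@H](CO)[C@@H](O)[C@H]2O)ccc1-c1ccccc1`: 2300 nM
Compound 3 `Nc1ncnc2c1nc(NCc1ccc(-c3ccccc3)cc1O)n2[C@@H]1O[C@H](CO)[C@@H](O)[C@H]1O`: 1300 nM

Of the compounds shown here, three have been tested in an assay on COS-7 cells for inhibition of sodium/nucleoside cotransporter 2 (Homo sapiens), read by scintillation counting; on this read-out lower numbers stand for stronger inhibition and higher numbers for weaker inhibition. Compound 2 gives 2300 nM, the second highest of the three numbers. Its nearest neighbour is compound 1, whose 2700 nM lies within the usual scatter of compound 2, and compound 3, with 1300 nM, is also within that scatter. The three values therefore cannot be ordered with confidence.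

Compound 4 `NC(=O)COc1cc(CNc2nc3c(N)ncnc3n2[C@@H]2O[C@H](CO)[C@@H](O)[C@H]2O)ccc1-c1ccccc1` has not yet been measured. It differs from compound 2 in one place: carbamoyl in place of methyl on a saturated chain carbon bound to an oxygen on an aromatic ring. Within the data shown here, no pair of measured compounds shows this particular change, so there is no measured step to lean on. The three compounds that are known span only a narrow band in this assay despite differing in the groups attached to the biphenyl-like portion.

Compound 4 is therefore expected to remain close to compound 2 in this assay, with the step of a 1.2-fold lower number from compound 2 to compound 4 (0.06 log units; within the scatter) expected to stay inside the scatter. The estimate for compound 4 is 2000 nM, with a likely range from 700 nM to 6000 nM.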

Compound 4, half-maximal inhibitory concentration: 5500 nM
Compound 4: middle estimate off by 2.8-fold (0.44 log units), on the low side; the range from low to high includes it.
By their numbers in this assay, from the lowest: compounds 3, 2 and 1 (each within the scatter of the next, the first and the last beyond it); then compound 4.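

In this assay, among these compounds, the change from ethoxy to carbamoylmethoxy gives a 2.4-fold higher number from compound 2 to compound 4 (0.38 log units; beyond the scatter) and is the only single-place step in this set. This shows that the chain on the oxygen at the aromatic ring is not indifferent to what it carries: exchanging methyl for carbamoyl, which brings a hydrogen-bond donor and acceptor, modestly weakens inhibition without abolishing it. No measurement shown accounts for this rise, so it stands as an observation only.

As far as these compounds go, whether the rise belongs to the carbamoyl group itself or simply to the longer chain remains open. A plain butyl chain on that oxygen would test chain length alone, while a carboxylic acid or an amine at the chain end would show how far the outcome depends on the terminal group.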